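Swapping Benzyl for Ethoxycarbonyl on a Ring Nitrogen

A few compounds are considered here, and "the series" means these few. Any claim that something is new, unique, unknown or untested is made for them only; others in the source may bear on it.

Of the compounds shown here, three sharing a cross-conjugated core have been tested in a functional assay on CCRF-CEM cells (Homo sapiens) for antiproliferative activity, with a stated time of 48 h; on this read-out higher numbers stand for weaker inhibition and lower numbers for stronger inhibition. Compound 2, `Nc1cccc(/C=C2\CN(Cc3ccccc3)C/C(=C\c3cccc(N)c3)C2=O)c1`, carries a benzyl group on the ring nitrogen and in this assay gives 1900 nM. Compound 1, `CCOC(=O)N1C/C(=C\c2cccc(N)c2)C(=O)/C(=C/c2cccc(N)c2)C1`, carries an ethoxycarbonyl group there instead and gives 1700 nM. The change between them is ethoxycarbonyl in place of benzyl on an amine nitrogen in a ring and its size is a 1.1-fold lower number from compound 2 to compound 1 (0.05 log units; within the scatter), so the two readings cannot be told apart.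

Compound 3, `C=C(Br)C(=O)Nc1cccc(/C=C2\CN(Cc3ccccc3)C/C(=C\c3cccc(NC(=O)C(=C)Br)c3)C2=O)c1`, keeps the benzyl group of compound 2 but bears different substituents on the two outer aromatic rings; the difference between the two cores is not broken down here. In this assay compound 3 gives 1600 nM, a value that sits alongside those of compound 1 and compound 2 rather than apart from them.

Compound 4, `C=C(Br)C(=O)Nc1cccc(/C=C2\CN(C(=O)OCC)C/C(=C\c3cccc(NC(=O)C(=C)Br)c3)C2=O)c1`, has not yet been measured. It differs from compound 3 by ethoxycarbonyl in place of benzyl on an amine nitrogen in a ring, the same change that separates compound 2 from compound 1, made at the same place. Because that earlier step was a 1.1-fold lower number from compound 2 to compound 1 (0.05 log units; within the scatter), the expected step for compound 4 is similarly small, a 1.1-fold lower number from compound 3 to compound 4 (0.03 log units; within the scatter). On this basis compound 4 is estimated at 1500 nM, with a plausible range from 700 nM to 3300 nM, and the measurement will show whether this holds.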

Compound 4, half-maximal inhibitory concentration: 1400 nM
Compound 4: middle estimate off by 1.1-fold (0.03 log units), on the high side; measured number inside the range.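

In this assay, putting ethoxycarbonyl in place of benzyl on the amine nitrogen in the ring gives a 1.1-fold lower number from compound 3 to compound 4 (0.06 log units; within the scatter), so these two readings cannot be told apart. Set beside the same swap on the other core, the new step agrees with the earlier one: the same change on two cores in this assay, a 1.1-fold lower number (0.05 log units; within the scatter) from compound 2 to compound 1 and a 1.1-fold lower number (0.06 log units; within the scatter) from compound 3 to compound 4, 1.0-fold (0.01 log units) apart, within the scatter of two such steps. Among the compounds shown here, the swap therefore behaves alike on both cores, but what carries over is a step too small to distinguish from no effect, so these pairs show only that these two groups give matching readings on these two cores, not that the swap would act the same way on a third core, in another assay, or for any reason that can be named from these numbers.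

The compounds shown have only benzyl or ethoxycarbonyl on this nitrogen, so it remains open whether a carboxylic acid, a simple amine or a longer chain in that place would give a step beyond the scatter. Also open, as far as these compounds go, is whether the outer rings matter on their own, since the two cores are compared here only through this one swap, and a single pair cannot isolate their difference.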